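The source may report more compounds than this note shows. Statements on the series, on what has been measured and on what is new or still open speak of the compounds shown alone.

Measured so far:
compound 1 `O=C(c1cccc(Nc2ncc(F)c(Nc3ccc(F)cc3)n2)c1)N1CCCCC1` — 14800 nM
compound 2 `O=C(NCCO)c1cccc(Nc2ncc(F)c(Nc3ccc(F)cc3)n2)c1` — 12400 nM
compound 3 `CN(C)CC(=O)Nc1cccc(Nc2ncc(F)c(Nc3ccc(F)cc3)n2)c1` — 1260 nM

In a functional assay on KB cells (Homo sapiens) for antiproliferative activity, read by sulforhodamine B assay, with a stated time of 3 days (a higher number here means a weaker inhibitor of growth, a lower number a stronger inhibitor of growth), compound 3 gives 1260 nM, the lowest of the three numbers, and both of its steps are beyond the scatter: a 12-fold lower number from compound 1 to compound 3 (1.07 log units; beyond the scatter) and a 9.8-fold lower number from compound 2 to compound 3 (0.99 log units; beyond the scatter). Compound 1 and compound 2 sit close together, with a 1.2-fold lower number from compound 1 to compound 2 (0.08 log units; within the scatter).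

Compound 4 `COc1ccc(NC(=O)c2cccc(Nc3ncc(F)c(Nc4ccc(F)cc4)n3)c2)cc1` is the next change from compound 3: (4-methoxyphenyl)carbamoyl in place of (((dimethylamino)methyl)carbonyl)amino on an aromatic carbon. The group that enters is a carbamoyl, as in the (piperidin-1-yl)carbonyl of compound 1 and the (2-hydroxyethyl)carbamoyl of compound 2, while the group that leaves is the (((dimethylamino)methyl)carbonyl)amino that sets compound 3 apart from both. The two steps that bear on this, from compound 1 to compound 3 and from compound 2 to compound 3, each went toward lower numbers and each lay beyond the scatter, and the step to compound 4 undoes the common feature of those changes. For the measured compounds named here, no step with a (4-methoxyphenyl)carbamoyl is known, so the size is uncertain, but a move back toward the range of compound 1 and compound 2 is expected.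

For compound 4 a number near 8000 nM is expected in this assay, within about 2500 nM to 25000 nM. This estimate means a step of a 6.3-fold higher number from compound 3 to compound 4 (0.80 log units; beyond the scatter) is expected.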

Compound 4, concentration for 50% growth inhibition: > 10000 nM
Compound 4: a limit, no number; the forecaster's own chance of this, stated with the estimate: 10%; middle value at least 1.2-fold (0.09 log units) away from the limit.
By their numbers in this assay, from the lowest: compound 3; then compounds 2 and 1 (each within the scatter of the next).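

Compound 4 gives > 10000 nM in this assay, which is a limit of the assay and not a number. The change gives an at least 7.9-fold higher number from compound 3 to compound 4 (0.89 log units; beyond the scatter); the group that enters and the group that leaves have the same counts of hydrogen-bond donors and acceptors, so those counts alone do not account for the lower number of compound 3, and a carbamoyl carrying a six-membered aromatic ring, with 11 heavy atoms, does not restore it at this position. The steps from compound 1 and from compound 2 to compound 4 cannot be read, so the order among the three carbamoyl compounds stays unknown because of the limit: the limit of > 10000 nM in this assay, at which 1 of the 4 values shown sits.

The compounds shown leave open whether the lower number of compound 3 goes with its dimethylamino group or with the attachment of its carbonyl through the amino nitrogen, since every step to compound 3 changes both together. An acetylamino group, a morpholine or a longer amine chain on the same amino-carbonyl link, or a carbamoyl bearing a dimethylaminoethyl chain, would separate these two features.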